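Oral exposure: acid replaced by imidazole on compound 1

The source may report more compounds than this note shows. Statements on the series, on what has been measured and on what is new or still open speak of the compounds shown alone.

Measured compounds:
compound 1 `CCCCN(c1nc2c(C(=O)O)cccc2o1)[C@H](C)c1ccc(-c2ccccc2-c2nnn[nH]2)cc1`: 429 ng.h/mL
compound 2 `C[C@H](c1ccc(-c2ccccc2-c2nc(=O)o[nH]2)cc1)N(CC1CC1)c1nc2c(C(=O)O)cccc2o1`: 11600 ng.h/mL
compound 3 `CCCCN(c1nc2c(C(=O)O)cccc2o1)[C@H](C)c1ccc(-c2cc(Cl)ccc2-c2nc(=O)o[nH]2)cc1`: 1040 ng.h/mL

In an ADME assay on the whole organism (Macaca fascicularis) for pharmacokinetics, read by LC-MS, using cassette dosing, at a dose of 1 mg/kg by the oral route (a higher number here means more compound in the circulation at the dose given, a lower number less compound in the circulation), compound 1 gives 429 ng.h/mL, the lowest of the three numbers. Compound 3 gives 1040 ng.h/mL, a gap beyond the scatter. Compound 2 gives 11600 ng.h/mL, the furthest off, well beyond the scatter. Going by the values given here, none of these three pairs differs in a single place, so their values are compared only as numbers, and no measured step on any one change is available.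

Compound 4 `CCCCN(c1nc2c(-c3nccn3C)cccc2o1)[C@H](C)c1ccc(-c2ccccc2-c2nnn[nH]2)cc1` differs from compound 1 by 1-methyl-1H-imidazol-2-yl in place of carboxy on an aromatic carbon. The tetrazole, the butyl chain and the shared core are kept. Among the compounds with values here, no measured pair in this set carries this exchange, so the expectation rests on compound 1 alone and on the general observation that the exposure numbers in this set spread widely.

For compound 4 in this assay the expected change is a small step upward, of a size that may not exceed the scatter, with considerable uncertainty in both directions. The estimate for compound 4 is 650 ng.h/mL, with a range from 150 ng.h/mL to 2800 ng.h/mL. The expected step is a 1.5-fold higher number from compound 1 to compound 4 (0.18 log units; within the scatter).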

Compound 4, area under the concentration-time curve: 152 ng.h/mL
The estimate for compound 4 lay 4.3-fold (0.63 log units) above the measured number, within the range that was stated.
By their numbers in this assay, from the lowest: compound 4; then compound 1; then compound 3; then compound 2.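

Working notes on the carboxy position: this is the first reading of a single-place change on this aromatic carbon of the six-membered aromatic ring of carbon only. In this assay, exchanging carboxy for 1-methyl-1H-imidazol-2-yl, with the tetrazole and the butyl chain kept, gives a 2.8-fold lower number from compound 1 to compound 4 (0.45 log units; beyond the scatter), a modest step that is beyond the scatter. For this one pair, the larger group with its five-membered aromatic ring and no hydrogen-bond donor lowers the number rather than raising it, and compound 4 now stands lowest of the four compounds. No measurement on hand accounts for the step, so it stands as an observation on a single pair.

From the compounds shown here alone, it remains open how a primary amide, a methyl ester or an imidazole without the methyl group would read at this same carbon, and so whether the drop belongs to this particular group or to the loss of carboxy in general. Going by these compounds, it is also open whether the same exchange would move the number in the same direction on the background of compound 2 or compound 3, both of which keep the carboxy group and carry a different ring in place of the tetrazole.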